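Solubility of a stereocentre pair in the series

A few compounds are considered here, and "the series" means these few. Any claim that something is new, unique, unknown or untested is made for them only; others in the source may bear on it.

In a physicochemical assay for solubility, read by HPLC, using the shake flask method, in phosphate buffer, with a stated time of 20 h, at pH 6.5 (a higher number here means a more soluble compound, a lower number a less soluble compound), compound 1 (`Fc1ccc(-c2nc3c(N4CCN5CCCC5C4)nccc3[nH]2)cc1F`) gives 120000 nM and compound 2 (`Fc1ccc(-c2nc3c(N4CCC(N5CCNCC5)CC4)nccc3[nH]2)cc1C(F)(F)F`) gives 200000 nM while compound 3 (`CN1CCN(C[C@@H]2CCCN(c3nccc4[nH]c(-c5cc(F)cc(F)c5)nc34)C2)CC1`) gives 145000 nM in the same read-out. Compound 3 stands within the scatter of both other compounds, so these numbers set no order among the three.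

Compound 4 (`CN1CCN(C[C@H]2CCCN(c3nccc4[nH]c(-c5cc(F)cc(F)c5)nc34)C2)CC1`) is the next to be read. It has the same atoms and bonds as compound 3, and the two compounds have the same atoms and bonds and differ only in configuration as drawn: 1 of 1 stereo elements differ; a stereocentre at a saturated ring carbon is drawn S in compound 3 and R in compound 4 with a stereocentre at a saturated ring carbon drawn S in compound 3 and R in compound 4.

Among the measured compounds shown here, no measured pair isolates a change of configuration, so the data give no direct size for this step. For the measured compounds named here, the only anchor is compound 3 at 145000 nM as the closest structure. The step expected no change at the digits printed from compound 3 to compound 4 (within the scatter) stays within the scatter, and no direction is expected. For compound 4 the estimated solubility is 145000 nM (85000 nM to 240000 nM).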

Compound 4, solubility: 200000 nM
Estimate against measurement, compound 4: 1.4-fold (0.14 log units) below; the measured number falls inside the stated range.
By their numbers in this assay, from the lowest: compounds 1, 3, 2 and 4 (each within the scatter of the next).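

Working notes on the stereocentre pair. Among the compounds shown here, the swap from S to R at the saturated ring carbon is the first change that can be read in one place, and in this assay it gives a 1.4-fold higher number from compound 3 to compound 4 (0.14 log units; within the scatter) in a pair that stays high in the range. The configuration at this ring carbon therefore shows no effect on the read-out that can be told from repeat scatter, and the size of the step can be tied to this single difference: (the fact that compounds 3 and 4 differ only in the configuration as drawn). Neither form can be ranked over the other, and this pair gives no basis for choosing a configuration on solubility alone.

As far as these compounds go, it remains open whether the same holds when a morpholine or a carboxylic acid is carried at this stereocentre in place of the present group. From the compounds shown here alone, it is also open whether a longer chain at the same carbon leaves the two configurations as close.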